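Ethoxy Enters the Amide Phenyl of Compound 3

The source may report more compounds than this note shows. Statements on the series, on what has been measured and on what is new or still open speak of the compounds shown alone.

The series shares one core, seen in compound 1 `O=C(/C=C/c1coc2cc(O)ccc2c1=O)NCc1ccc(F)cc1`. In a functional assay on Huh-7 cells (Homo sapiens) for inhibition, read by MTT assay, with a stated time of 48 h (on this read-out lower numbers stand for stronger inhibition and higher numbers for weaker inhibition), compound 1 gives > 100000 nM, which is a limit of the assay rather than a number. Compound 2 `COc1ccc2c(=O)c(/C=C/C(=O)NCc3cccc(F)c3)coc2c1` gives 10100 nM in this assay, and compound 3 `COc1ccc2c(=O)c(/C=C/C(=O)Nc3ccccc3)coc2c1` gives 9050 nM. Among the measured compounds shown here, the one measured step, a 1.1-fold lower number from compound 2 to compound 3 (0.05 log units; within the scatter), leaves compound 2 and compound 3 within the scatter of each other; the remaining value of the three is a limit, so compound 3 stands alongside compound 2 with no separation that can be trusted.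

Compound 4 `CCOc1ccc(NC(=O)/C=C/c2coc3cc(OC)ccc3c2=O)cc1` is the next member. Its difference from compound 3 is ethoxy in place of hydrogen on an aromatic carbon. For the measured compounds named here, the only measured step, from compound 2 to compound 3, also altered the group on the amide nitrogen, and it stayed within the scatter, so the data carry no step in which a substituent is added to the phenyl on that nitrogen. Going by the values given here, no measured step therefore points to a change beyond the scatter in either direction.

Compound 4 is expected to give about 8000 nM in this assay, within a range from 3000 nM to 25000 nM, which is an estimated step of a 1.1-fold lower number from compound 3 to compound 4 (0.05 log units; within the scatter).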

Compound 4, half-maximal inhibitory concentration: 3230 nM
Estimate against measurement, compound 4: 2.5-fold (0.39 log units) above; the range from low to high includes it.
By their numbers in this assay, from the lowest: compound 4; then compounds 3 and 2 (each within the scatter of the next). At a limit, above all of these: compound 1.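

In this assay, the phenyl on the amide nitrogen turns out to be a place where a single change moves the number beyond the scatter, since ethoxy in place of hydrogen gives a 2.8-fold lower number from compound 3 to compound 4 (0.45 log units; beyond the scatter). Among the compounds shown here, the earlier compounds could not show this: their one measured step, a 1.1-fold lower number from compound 2 to compound 3 (0.05 log units; within the scatter), exchanged the whole group on that nitrogen and stayed within the scatter, so it left open whether that part of the molecule responds at all. The 4-ethoxyphenyl group also separates from the 3-fluorobenzyl group, with a 3.1-fold lower number from compound 2 to compound 4 (0.50 log units; beyond the scatter), a separation that the unsubstituted phenyl of compound 3 did not give.

Nothing given here bears on the reason for the ethoxy step. On these data alone, the step also rests on a single substituent on a single ring, so it remains open whether a longer chain such as butoxy, an amine or a carboxylic acid in the same place would lower the number further, leave it unchanged or raise it.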